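The source may report more compounds than this note shows. Statements on the series, on what has been measured and on what is new or still open speak of the compounds shown alone.

In an ADME assay on the whole organism (plasma, strain 129/SvEvBrd x C57BL/6) for pharmacokinetics, with Mus musculus as the target, at a dose of 10 mg/kg by the oral route (a lower number here means less compound in the circulation, a higher number more compound in the circulation at the dose given), compound 2 `CC(O)c1nc([C@@H](O)[C@H](O)[C@H](O)CO)c[nH]1` gives 10300 ng.h/mL, a number within the usual scatter of compound 1 `CC(=O)c1cccc([C@@H](O)[C@H](O)[C@H](O)CO)n1`, which gives 10500 ng.h/mL. Compound 3 `OC[C@@H](O)[C@@H](O)[C@H](O)c1c[nH]c(-c2ncc[nH]2)n1` has not yet been measured. It carries 1H-imidazol-2-yl in place of 1-hydroxyethyl on an aromatic carbon, between two ring nitrogen atoms (1H-imidazol-2-yl in place of 1-hydroxyethyl on an aromatic carbon). Going by the values given here, no measured step between these compounds guides the expectation, so only a modest fall in this assay is anticipated, with the estimated change being a 2.3-fold lower number from compound 2 to compound 3 (0.36 log units; beyond the scatter). Compound 3 is expected to give 4500 ng.h/mL. The estimated range for compound 3 runs from 1300 ng.h/mL to 14000 ng.h/mL.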

Compound 3, area under the concentration-time curve: 1500 ng.h/mL
Compound 3: middle estimate off by 3.0-fold (0.48 log units), on the high side, and the stated range covers the measured number.
By their numbers in this assay, from the lowest: compound 3; then compounds 2 and 1 (each within the scatter of the next).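

In this assay the change shows a 6.9-fold lower number from compound 2 to compound 3 (0.84 log units; beyond the scatter) when 1H-imidazol-2-yl takes the place of 1-hydroxyethyl on this aromatic carbon, between two ring nitrogen atoms. The earlier compounds shown here offered no step at this position, and this one shows that the number responds to the group placed here, even though both groups count the same hydrogen-bond donors and acceptors and carry no net charge. Nothing measured here explains the fall.

As far as these compounds go, what an amine, a carboxylic acid or a longer chain on this carbon would give remains open, as does whether any aromatic ring here would bring a similar fall.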